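From 4-methoxybenzyl to furan-3-yl on the shared core

The source may report more compounds than this note shows. Statements on the series, on what has been measured and on what is new or still open speak of the compounds shown alone.

Compound 1 `CCOC(=O)c1ccc(-c2nn(Cc3ccccc3F)c3ccccc23)cc1`: 110 nM
Compound 2 `CCOC(=O)c1ccc(-c2nn(Cc3cccc(OC)c3)c3ccccc23)cc1`: 260 nM
Compound 3 `CCOC(=O)c1ccc(-c2nn(Cc3ccc(OC)cc3)c3ccccc23)cc1`: 620 nM

All three compounds were tested in a functional assay on cells (Platelet, Homo sapiens) for inhibition; a lower number here means a stronger inhibitor, a higher number a weaker inhibitor. Compound 3 gives 620 nM, the highest number of the three, which makes it the weakest inhibitor of this small set. Compound 4 `CCOC(=O)c1ccc(-c2nn(-c3ccoc3)c3ccccc23)cc1` has not yet been measured. It carries furan-3-yl in place of 4-methoxybenzyl on an aromatic nitrogen.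

Two measured steps change the same group of compound 3: a 5.6-fold higher number from compound 1 to compound 3 (0.75 log units; beyond the scatter) and a 2.4-fold higher number from compound 2 to compound 3 (0.38 log units; beyond the scatter). Both are modest, and a 2.4-fold higher number from compound 1 to compound 2 (0.37 log units; beyond the scatter) is modest too. For the measured compounds named here, none of the measured compounds carries furan-3-yl, so these steps offer only a rough guide to size and no firm direction. A modest step in this assay is therefore expected, with a slightly higher number as the cautious guess. The estimated change is a 1.6-fold higher number from compound 3 to compound 4 (0.21 log units; within the scatter). For compound 4 the expected value is 1000 nM, with an estimated range of 150 nM to 5000 nM.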

Compound 4, half-maximal inhibitory concentration: 580 nM
Compound 4: middle estimate off by 1.7-fold (0.24 log units), on the high side; low and high end bracket the measured number.
By their numbers in this assay, from the lowest: compound 1; then compound 2; then compounds 4 and 3 (each within the scatter of the next).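

In this assay, furan-3-yl in place of 4-methoxybenzyl gives a 1.1-fold lower number from compound 3 to compound 4 (0.03 log units; within the scatter), so this aromatic nitrogen tolerates a smaller ring of 5 heavy atoms, with a hetero atom and without the saturated chain carbon, and the number stays level. Against the other two benzyl compounds the furan-3-yl compound shows a 2.2-fold higher number from compound 2 to compound 4 (0.35 log units; beyond the scatter) and a 5.3-fold higher number from compound 1 to compound 4 (0.72 log units; beyond the scatter), leaving the 2-fluorobenzyl group of compound 1 with the lowest number of these four. No measurement available here accounts for these differences or for the level result.

A simple ethyl chain, or a chain ending in an amine, on this nitrogen would test whether a ring is needed there at all. A furan-3-ylmethyl group would separate the change of ring from the loss of the chain carbon.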